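Trifluoromethyl for fluoro: expecting the next cytotoxicity reading

This account rests on a few compounds, and the source may have more. Where it says the series, first, only, none or still open, it means among the compounds named here.

Compound 1 is `N#Cc1c(-c2ccc(F)cc2)c(C#N)c(=O)n(/N=C/c2cn(-c3ccccc3)nc2-c2ccccc2)c1N`. In an ADME assay on NIH3T3 cells (Mus musculus) for cytotoxicity, read by MTT assay (a higher number here means a weaker inhibitor, a lower number a stronger inhibitor), compound 1 gives only a limit, > 200 ug/mL, not a number. Compound 2, `COc1cc(-c2c(C#N)c(N)n(/N=C/c3cn(-c4ccccc4)nc3-c3ccccc3)c(=O)c2C#N)cc(OC)c1OC`, carries a 3,4,5-trimethoxyphenyl in place of the 4-fluorophenyl on an aromatic carbon, and in this assay compound 2 gives 64 ug/mL. That step, an at least 3.1-fold lower number from compound 1 to compound 2 (0.49 log units; beyond the scatter), is the only measured one, and its size is known only loosely because of the limit of > 200 ug/mL in this assay, at which 1 of the 2 values shown sits.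

Compound 3 is `N#Cc1c(-c2ccc(C(F)(F)F)cc2)c(C#N)c(=O)n(/N=C/c2cn(-c3ccccc3)nc2-c2ccccc2)c1N`. It differs from compound 1 by trifluoromethyl in place of fluoro on an aromatic carbon. Among the compounds with values here, no measured step changes this group, so the trimethoxyphenyl step is at best a distant guide: it shows that altering the aryl ring can lower the number, but the change here is far smaller. Compound 1 sits at the limit, and a small change at this position is expected to leave compound 3 near it, possibly a little lower. Compound 3 is therefore estimated at 150 ug/mL, with a range from 60 ug/mL to 300 ug/mL. The expected step is an at least 1.3-fold lower number from compound 1 to compound 3 (0.12 log units; that floor lies within the scatter).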

Compound 3, half-maximal inhibitory concentration: > 200 ug/mL
Compound 3 ended at the assay's limit; the forecaster's own chance of this, stated with the estimate: 50%; middle value at least 1.3-fold (0.12 log units) away from the limit.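

In this assay, putting 4-(trifluoromethyl)phenyl in place of 3,4,5-trimethoxyphenyl on this aromatic carbon gives an at least 3.1-fold higher number from compound 2 to compound 3 (0.49 log units; beyond the scatter). The earlier compounds showed this contrast with 4-fluorophenyl alone, and it now holds for a second aryl group, so among the compounds shown the readable number goes with the 3,4,5-trimethoxyphenyl only. Compound 1 and compound 3 each give only a limit and not a number, so the step between them cannot be read, and the effect of trifluoromethyl in place of fluoro has no measurable size, because both compounds stop at the same ceiling: the limit of > 200 ug/mL in this assay, at which 2 of the 3 values shown sit.

Going by these compounds, what stays open is whether a smaller change could also bring the number down to a readable value, for example an amine or a carboxylic acid in place of the fluoro on the same ring. It is also unknown whether the methoxy groups of compound 2 are all needed, since a phenyl ring carrying only one or two of them is not among the compounds shown here.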